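Chain Extension at the Acid Group on the Shared Core

A few compounds are considered here, and "the series" means these few. Any claim that something is new, unique, unknown or untested is made for them only; others in the source may bear on it.

Measured compounds:
compound 1 `Cc1cc(C(=O)O)ccc1-c1noc(-c2ccc(C3CCCCC3)cc2)n1` — > 10000 nM
compound 2 `Cc1cc(CC(=O)O)ccc1-c1noc(-c2ccc(C3CCCCC3)cc2)n1` — > 10000 nM

In a functional assay on CHO cells with sphingosine 1-phosphate receptor 2 (Homo sapiens) as the target, read by GTPgammaS binding (on this read-out lower numbers stand for an effect already at smaller amounts and higher numbers for an effect only at larger amounts of compound), compound 1 gives only a limit, > 10000 nM, not a number. Compound 2 likewise gives only a limit in this assay, > 10000 nM. For the measured compounds named here, both values therefore sit at the limit of > 10000 nM in this assay, at which 2 of the 2 values shown sit, and the one step between them, a step that the two limits leave unreadable from compound 1 to compound 2, cannot be read, because both ends are limits.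

Compound 3 `Cc1cc(CCC(=O)O)ccc1-c1noc(-c2ccc(C3CCCCC3)cc2)n1` differs from compound 2 by carboxymethyl in place of carboxy on a saturated chain carbon bound to an aromatic carbon; the same difference, cut one bond further out, reads carboxymethyl to 2-carboxyethyl. Going by the values given here, the only measured step, from compound 1 to compound 2, is the same kind of chain lengthening at the acid, and it gave no readable size. Among the compounds with values here, no step on record thus says which way this assay moves when the chain grows by one more carbon, and the values for both known compounds lie at the limit.

Compound 3 is accordingly expected at 15000 nM, within a range from 3000 nM to 60000 nM, most probably again reported as a limit. The step that this estimate means, a step that the limit leaves unreadable from compound 2 to compound 3, is expected to be indistinguishable from no change.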

Compound 3, half-maximal effective concentration: > 10000 nM
Compound 3 ended at the assay's limit (the forecaster's own chance of this, stated with the estimate: 80%); the middle value is on the limit's open side.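

In this assay compound 3 gives only a limit, > 10000 nM. For the compounds shown here, no step among compound 1, compound 2 and compound 3 can be read, because all three stand at the same limit: the limit of > 10000 nM in this assay, at which 3 of the 3 values shown sit. The compounds shown leave open whether any change on the shared core would yield an actual number in this assay.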